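This account rests on a few compounds, and the source may have more. Where it says the series, first, only, none or still open, it means among the compounds named here.

Measured compounds in an assay on isolated protein for inhibition of Amine oxidase [flavin-containing] B (Homo sapiens); a higher number here means a weaker inhibitor, a lower number a stronger inhibitor:
- compound 1, `C#CCNC1CCc2c(SCCc3cccc(Cl)c3)cccc21`, gives 82400 nM
- compound 2, `C#CCNC1CCc2c(SCCc3cccc(C)c3)cccc21`, gives 0.35 nM
- compound 3, `C#CCNC1CCc2c(OCc3cccc(C(F)(F)F)c3)cccc21`, gives 6410 nM

Compound 2 gives the lowest number of the three, far from compound 3 and furthest from compound 1. Compound 4, `C#CCNC1CCc2c(SCCc3cccc(OC)c3)cccc21`, is not yet measured. It differs from compound 2 in one place: methoxy in place of methyl on an aromatic carbon. Going by the values given here, only one measured step touches this position, a 240000-fold lower number from compound 1 to compound 2 (5.37 log units; beyond the scatter), which shows that a single small group on that ring can shift this assay enormously. Among the compounds with values here, no measured pair shows methoxy against methyl, so the direction is uncertain. Given how far compound 2 already lies below the others, a sizeable weakening is the expected outcome, as a step of an 86-fold higher number from compound 2 to compound 4 (1.93 log units; beyond the scatter). Compound 4 is estimated at 30 nM, between 0.3 nM and 3000 nM.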

Compound 4, half-maximal inhibitory concentration: 28700 nM
For compound 4 the middle estimate is 960-fold (2.98 log units) below the measured one; measured number outside the range, above it.
By their numbers in this assay, from the lowest: compound 2; then compound 3; then compound 4; then compound 1.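

In this assay, the methyl of compound 2 turns out to be the exception at this position, not the chloro of compound 1: methoxy brings an 82000-fold higher number from compound 2 to compound 4 (4.91 log units; beyond the scatter), whereas replacing chloro with methoxy brings only a 2.9-fold lower number from compound 1 to compound 4 (0.46 log units; beyond the scatter). Two quite different replacements for methyl thus both leave very weak inhibitors. Nothing available explains this gap. As far as these compounds go, whether an ethyl group, an amine or a fluorine on this carbon would keep the strength of compound 2 remains open.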